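Compound 3: an exchange with no expected step

This account rests on a few compounds, and the source may have more. Where it says the series, first, only, none or still open, it means among the compounds named here.

Measured in a functional assay on SGC-7901 cells (Homo sapiens) for cytotoxicity, read by MTT assay, with a stated time of 38 h; a lower number here means a stronger inhibitor, a higher number a weaker inhibitor:
- compound 1 `COc1cc(OC)c2c(=O)c(OCC(=O)N/N=C/c3ccccc3F)c(-c3cc(OC)c(OC)c(OC)c3)oc2c1` gives 7720 nM
- compound 2 `COc1cc(OC)c2c(=O)c(OCCCCN3CCN(C)CC3)c(-c3cc(OC)c(OC)c(OC)c3)oc2c1` gives 6950 nM

The two values lie within the scatter of each other, so compound 2 holds no distinct rank in the series. The next structure, compound 3 `COc1cc(OC)c2c(=O)c(OCC(=O)N/N=C/c3ccco3)c(-c3cc(OC)c(OC)c(OC)c3)oc2c1`, differs from compound 2 as follows: a group of 10 heavy atoms (6 carbon, 2 nitrogen, 2 oxygen; one five-membered aromatic ring with 1 hetero atom) in place of a group of 10 heavy atoms (8 carbon, 2 nitrogen; one six-membered non-aromatic ring with 2 hetero atoms), on a saturated chain carbon bound to an oxygen on an aromatic ring. Among the compounds with values here, the new group brings in a five-membered aromatic ring with 1 hetero atom, and no measured compound carries such a ring.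

Within the data shown here, one measured step bears on this exchange: a 1.1-fold lower number from compound 1 to compound 2 (0.05 log units; within the scatter). It replaced a different group at the same place and stayed within the scatter. The group in compound 1 is also the nearest measured match to the group entering compound 3, and compound 1 gives 7720 nM. Two compounds are thin evidence, so the range is kept wide, and no step beyond the scatter is expected in this assay. The expected step is a 1.0-fold higher number from compound 2 to compound 3 (0.00 log units; within the scatter). For compound 3 the estimated value is 7000 nM, with an expected range from 2500 nM to 18000 nM.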

Compound 3, half-maximal inhibitory concentration: 5720 nM
Beside the measured number, compound 3's estimate is 1.2-fold (0.09 log units) above it, and the stated range covers the measured number.
By their numbers in this assay, from the lowest: compounds 3, 2 and 1 (each within the scatter of the next).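

In this assay, the exchange on a saturated chain carbon bound to an oxygen on an aromatic ring gives a 1.2-fold lower number from compound 2 to compound 3 (0.08 log units; within the scatter) where the 3-(4-methylpiperazin-1-yl)propyl group leaves, so a group with a five-membered aromatic ring with 1 hetero atom stays within the scatter of the group with a six-membered non-aromatic ring. The series now also has a step confined to a carbon with a double bond to nitrogen: furan-2-yl in place of 2-fluorophenyl gives a 1.3-fold lower number from compound 1 to compound 3 (0.13 log units; within the scatter) and also stays within the scatter, so this exchange of rings does not separate the two compounds in this assay. Nothing measured here offers an explanation for either step.

Whether any group at these places gives a step beyond the scatter stays open, since all the steps shown lie within it. A carboxylic acid or a longer chain in place of the present groups, or a pyridine ring in place of furan-2-yl, would test whether the values in this series can move at all.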